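Adding Chlorine to a Phenyl Ether Series

The compounds below may be only part of what the source reports. "The series", "measured", "known", "first", "only" and "open" are said of these compounds alone.

Measured so far:
Compound 1, `c1ccc(COc2ccc3c(c2)OCCO3)cc1`: 168 nM
Compound 2, `Clc1cccc(COc2ccc3c(c2)OCCO3)c1`: 57 nM
Compound 3, `c1ccc(OCCOc2ccc3c(c2)OCCO3)cc1`: 109 nM

All three were tested in an assay on isolated protein for inhibition of Amine oxidase [flavin-containing] B (Homo sapiens), read by fluorescence and spectrophotometry; on this read-out lower numbers stand for stronger inhibition and higher numbers for weaker inhibition. Compound 1 and compound 2 share a core and differ in one place: chloro in place of hydrogen on an aromatic carbon. This change gave a 2.9-fold lower number from compound 1 to compound 2 (0.47 log units; beyond the scatter). Compound 3 has a different core; the difference between the two cores is not broken down here. Its value lies within the usual scatter of both compound 1 and compound 2, so nothing is said about their order.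

Compound 4, `Clc1ccc(OCCOc2ccc3c(c2)OCCO3)cc1`, has not been measured. It differs from compound 3 in one place: chloro in place of hydrogen on an aromatic carbon. This is the same kind of change as from compound 1 to compound 2, but here the chlorine sits para to a large group rather than meta to it, so the earlier step is only a guide. In this assay the step is expected to be a 2.2-fold lower number from compound 3 to compound 4 (0.34 log units; beyond the scatter), resting on a 2.9-fold lower number from compound 1 to compound 2 (0.47 log units; beyond the scatter). Compound 4 is therefore estimated at 50 nM, with a likely range from 20 nM to 130 nM.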

Compound 4, half-maximal inhibitory concentration: 348 nM
Beside the measured number, compound 4's estimate is 7.0-fold (0.84 log units) below it; measured number above the stated range.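

In this assay, the chloro in place of hydrogen gave a 3.2-fold higher number from compound 3 to compound 4 (0.50 log units; beyond the scatter), so the change that strengthened inhibition on the core of compound 1 weakened it on the core of compound 3, and the two results clearly differ: the same change on two cores in this assay, a 2.9-fold lower number (0.47 log units; beyond the scatter) from compound 1 to compound 2 and a 3.2-fold higher number (0.50 log units; beyond the scatter) from compound 3 to compound 4, 9.4-fold (0.97 log units) apart, beyond the scatter of two such steps In this series, then, the earlier gain cannot be assumed to carry from one core to another. These two pairs do not show why the results differ, since the cores differ and the chlorine also sits at a different ring place in compound 2 than in compound 4.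

The compounds shown leave open what a chlorine at the ring place seen in compound 2 would do on the core of compound 3. They also leave open whether a fluorine or a methoxy group in place of the chlorine of compound 4 would follow the same course.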